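Series notes: bromo in place of hexyloxy on compound 1

The compounds below may be only part of what the source reports. "The series", "measured", "known", "first", "only" and "open" are said of these compounds alone.

Measured so far:
compound 1 `CCCCCCOc1ccc2c(c1)C=C(CN(O)C(N)=O)CO2` — 280 nM
compound 2 `NC(=O)N(O)CC1=Cc2cc(OCCCc3ccccc3)ccc2OC1` — 130 nM
compound 3 `O=C(NCc1ccccc1)N(O)CC1=Cc2cc(Oc3ccccc3)ccc2OC1` — 440 nM

In an assay (Cavia porcellus) for inhibition of Polyunsaturated fatty acid 5-lipoxygenase (Homo sapiens) (a higher number here means a weaker inhibitor, a lower number a stronger inhibitor), compound 1 stands second highest of the three numbers. Compound 3 gives 440 nM, within the scatter of compound 1. Going by the values given here, the only single-point change measured is a 2.2-fold lower number from compound 1 to compound 2 (0.33 log units; beyond the scatter), a modest shift that goes beyond the scatter. Compound 4 `NC(=O)N(O)CC1=Cc2cc(Br)ccc2OC1` carries bromo in place of hexyloxy on an aromatic carbon. Among the compounds with values here, no measured step bears on this change: the one step known alters the far end of the chain, whereas here the whole hexyloxy group is gone. Any expectation is therefore loosely held and rests on the spread of the three numbers only. Compound 4 is expected to give 1500 nM, with a range of 400 nM to 6000 nM. This corresponds to an expected step of a 5.4-fold higher number from compound 1 to compound 4 (0.73 log units; beyond the scatter), toward a weaker inhibitor.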

Compound 4, half-maximal inhibitory concentration: 1400 nM
Compound 4: middle estimate off by 1.1-fold (0.03 log units), on the high side; the measured number falls inside the stated range.
By their numbers in this assay, from the lowest: compound 2; then compounds 1 and 3 (each within the scatter of the next); then compound 4.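

In this assay, bromo in place of hexyloxy on the aromatic carbon gives a 5.0-fold higher number from compound 1 to compound 4 (0.70 log units; beyond the scatter). The whole chain can therefore leave this position at the cost of a modest step, whereas the earlier step, a 2.2-fold lower number from compound 1 to compound 2 (0.33 log units; beyond the scatter), only altered the far end of the chain. Nothing available accounts for the size of this step.

Still open, as far as these compounds go, is where a methoxy group, a shorter alkoxy chain or an amine on this carbon would fall relative to compound 1 and compound 4. Also open, from the compounds shown here alone, is whether chain length or the oxygen on the aromatic ring matters more.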